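The compounds below may be only part of what the source reports. "The series", "measured", "known", "first", "only" and "open" are said of these compounds alone.

In an ADME assay on BCBL1 cells (Homo sapiens) for cytotoxicity, with a stated time of 7 days (on this read-out lower numbers stand for higher toxicity in this test and higher numbers for lower toxicity in this test), compound 1 `CCOc1nc(N)nc2c1ncn2/C=C1/CC1(CO)CO` gives > 20000 nM as a limit of the assay, not a number. Compound 2 `CC(C)Nc1nc(N)nc2c1ncn2/C=C1/CC1(CO)CO` gives > 20000 nM as a limit too. For the measured compounds named here, that leaves the limit of > 20000 nM in this assay, at which 2 of the 2 values shown sit, as the only evidence so far. Compound 3 `Nc1nc(NC2CCCC2)c2ncn(/C=C3/CC3(CO)CO)c2n1` differs from compound 2 by cyclopentyl in place of isopropyl on a nitrogen on an aromatic ring with cyclopentyl in place of isopropyl on a nitrogen on an aromatic ring. Going by the values given here, the only measured step is a step that the two limits leave unreadable from compound 1 to compound 2 and offers no size to carry over, so no shift in this assay beyond the scatter is expected. The expected change is a number no higher from compound 2 to compound 3 (the limit leaves the size open) on this estimate. Compound 3 is estimated at 20000 nM within a range of 8000 nM to 50000 nM for now.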

Compound 3, half-maximal cytotoxic concentration: 71700 nM
For compound 3 the middle estimate is 3.6-fold (0.55 log units) below the measured one, outside the stated range (above it).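

No step can be read among compound 1, compound 2 and compound 3, as compound 1 and compound 2 carry limits, not numbers. As far as these compounds go, how much swapping ethoxy, isopropylamino and cyclopentylamino shifts the result in this assay stays open.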